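Replacing the aryl group of compound 1

A few compounds are considered here, and "the series" means these few. Any claim that something is new, unique, unknown or untested is made for them only; others in the source may bear on it.

In an ADME assay on the whole organism for cytotoxicity, with Artemia salina as the target, with a stated time of 24 h (on this read-out higher numbers stand for an effect only at larger amounts of compound and lower numbers for an effect already at smaller amounts), compound 1 (`Cc1ccc(S(=O)(=O)NC(=O)Nc2ccccc2C(=O)/C=C/c2ccc(N(C)C)cc2)cc1`) gives 38.1 ug/mL. Compound 2 (`COc1cccc(/C=C/C(=O)c2ccccc2NC(=O)NS(=O)(=O)c2ccc(C)cc2)c1`) gives 23.2 ug/mL, and compound 3 (`COc1ccc(/C=C/C(=O)c2ccccc2NC(=O)NS(=O)(=O)c2ccc(C)cc2)cc1`) gives 28.1 ug/mL. These three numbers lie within the scatter of one another, so compound 1 does not stand apart from the other two.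

Compound 4 (`CCc1cc(/C=C/C(=O)c2ccccc2NC(=O)NS(=O)(=O)c2ccc(C)cc2)cc(OC)c1OC`) has not yet been measured. Its structural change is 3-ethyl-4,5-dimethoxyphenyl in place of 4-(dimethylamino)phenyl on a double-bonded chain carbon bound to a double-bonded chain carbon.

Among the measured compounds shown here, three measured steps bear on this change. Two replace 4-(dimethylamino)phenyl with a methoxy-bearing phenyl: a 1.6-fold lower number from compound 1 to compound 2 (0.22 log units; within the scatter) and a 1.4-fold lower number from compound 1 to compound 3 (0.13 log units; within the scatter). The third is a 1.2-fold higher number from compound 2 to compound 3 (0.08 log units; within the scatter), with 4-methoxyphenyl in place of 3-methoxyphenyl. All three stay within the scatter. For the measured compounds named here, no measured compound carries 3-ethyl-4,5-dimethoxyphenyl, so the data do not test this group directly.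

On these steps, no change beyond the scatter is expected in this assay. The estimated step is a 1.5-fold lower number from compound 1 to compound 4 (0.17 log units; within the scatter). For compound 4, the estimated value is 26 ug/mL, with an expected range of 12 ug/mL to 55 ug/mL.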

Compound 4, concentration for half-maximal effect: 19.2 ug/mL
For compound 4 the middle estimate is 1.4-fold (0.13 log units) above the measured one, within the range that was stated.
By their numbers in this assay, from the lowest: compounds 4, 2, 3 and 1 (each within the scatter of the next).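

In this assay, the place on a double-bonded chain carbon bound to a double-bonded chain carbon now holds a group of 12 heavy atoms, and the number stays within the scatter of all three earlier compounds (a 2.0-fold lower number from compound 1 to compound 4 (0.30 log units; within the scatter); a 1.5-fold lower number from compound 3 to compound 4 (0.17 log units; within the scatter); a 1.2-fold lower number from compound 2 to compound 4 (0.08 log units; within the scatter)). Adding an ethyl and a second methoxy to a methoxy-bearing phenyl therefore brings no change that can be told from the scatter, and all four compounds remain one group on this read-out. Nothing on hand accounts for this flat result.

Every group shown here is a phenyl carrying methoxy, ethyl or dimethylamino, so the effect of a carboxylic acid or a nitrile on that phenyl remains open. Also open, on these data alone, is whether any change elsewhere on the shared core would move the number beyond the scatter.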